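This account rests on a few compounds, and the source may have more. Where it says the series, first, only, none or still open, it means among the compounds named here.

In a functional assay on BXPC-3 cells (Homo sapiens) for inhibition, read by XTT assay, with a stated time of 72 h (on this read-out higher numbers stand for weaker inhibition and lower numbers for stronger inhibition), compound 3 (`C=CCCCCCCCCCOC[C@@H]1CCCN1[S+]([O-])c1ccc(C)cc1`) gives 50000 nM, the higher of the two actual numbers in this small set. Compound 2 (`CCCCCCCC/C=C\CCCCCCCCOC[C@@H]1CCCN1`) gives the lower number, 5300 nM. Compound 1 (`CCCCCCCC/C=C\CCCCCCCCOC[C@@H]1CCCN1C(=O)OC(C)(C)C`) reads > 100000 nM, which is a limit of the assay and not a number.

Compound 4 (`CCCCCCCC/C=C\CCCCCCCCOC[C@@H]1CCCN1[S+]([O-])c1ccc(C)cc1`) keeps the group on the ring nitrogen of compound 3 and changes only the chain: dec-1-en-1-yl in place of allyl on a saturated chain carbon, eight bonds along the chain from an oxygen on a saturated carbon. Here dec-1-en-1-yl takes the place of allyl, eight bonds along the chain from an oxygen on a saturated carbon.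

For the measured compounds named here, the one measured step, an at least 18-fold lower number from compound 1 to compound 2 (1.27 log units; beyond the scatter), is large, but it puts hydrogen in place of tert-butoxycarbonyl on the nitrogen and leaves the chain alone. Going by the values given here, it therefore bears on this change only indirectly, and no measured pair isolates the chain. The longer chain does occur in compound 2, at 5300 nM. It also occurs in compound 1, where > 100000 nM is a limit of the assay.

A modest move towards a lower number is expected in this assay, an estimated 2.5-fold lower number from compound 3 to compound 4 (0.40 log units; beyond the scatter). Compound 4 is estimated at 20000 nM, with an expected range of 6000 nM to 90000 nM.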

Compound 4, half-maximal inhibitory concentration: > 100000 nM
Compound 4: only a limit was reported; the forecaster's own chance of this, stated with the estimate: 20%; middle value at least 5.0-fold (0.69 log units) from the limit.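

With the group on the ring nitrogen kept, dec-1-en-1-yl in place of allyl gives an at least 2.0-fold higher number from compound 3 to compound 4 (0.30 log units; that floor lies within the scatter) in this assay, so the expected fall did not appear, although the size of any rise remains unclear. With the longer chain kept, the group of 9 heavy atoms in place of hydrogen on the ring nitrogen gives an at least 18-fold higher number from compound 2 to compound 4 (1.27 log units; beyond the scatter), so the longer chain alone does not secure the lower number of compound 2. Compound 4 reads only as a limit of the assay, as does compound 1, so the step between them cannot be read: the limit of > 100000 nM in this assay, at which 2 of the 4 values shown sit.

A chain of intermediate length between allyl and dec-1-en-1-yl could show where the number starts to rise. A methyl or acetyl group on the ring nitrogen could show how the number responds to a smaller group there.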